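The compounds below may be only part of what the source reports. "The series", "measured", "known", "first", "only" and "open" are said of these compounds alone.

Compound 1, `O=C1C(Nc2ccc(CO)cc2)=CC(=O)c2ncncc21`: 3500 nM
Compound 2, `COc1cccc(NC2=CC(=O)c3ncncc3C2=O)c1`: 1800 nM
Compound 3, `O=C1C(Nc2cccc(B(O)O)c2)=CC(=O)c2ncncc21`: > 10000 nM

The three measured compounds share one core and differ only in the group carried on the aromatic ring that hangs from the amine. In a functional assay on MIA PaCa-2 cells (Homo sapiens) for cytotoxicity, read by MTT assay, with a stated time of 72 h (a lower number here means a stronger inhibitor, a higher number a weaker inhibitor), compound 1 gives 3500 nM, the highest of the two numbers that are actual numbers; compound 2 gives 1800 nM, which lies within the usual scatter of compound 1, so no order between the two can be claimed. Compound 3 sits at > 10000 nM, a limit of the assay rather than a number (the limit of > 10000 nM in this assay, at which 1 of the 3 values shown sits).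

Among the compounds with values here, the only step that can be sized is an at least 5.5-fold higher number from compound 2 to compound 3 (0.74 log units; beyond the scatter), where exchanging one small group on that ring for another gave a clearly weaker inhibitor.

Compound 4, `NS(=O)(=O)c1ccc(NC2=CC(=O)c3ncncc3C2=O)cc1`, has not yet been measured. It differs from compound 1 by sulfamoyl in place of hydroxymethyl on an aromatic carbon. Within the data shown here, the step from compound 2 to compound 3 is the only measured change of a group on this ring, and it went toward a weaker inhibitor, but it concerned a different pair of groups, so it bears only loosely on the present change. A shift of modest size toward a higher number, or none beyond the scatter, is therefore expected in this assay, written as a 1.4-fold higher number from compound 1 to compound 4 (0.15 log units; within the scatter). For compound 4 the expected value is 5000 nM, estimated to fall between 2000 nM and 13000 nM.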

Compound 4, half-maximal inhibitory concentration: > 10000 nM
Compound 4: a limit, no number (the forecaster's own chance of this, stated with the estimate: 20%); middle value at least 2.0-fold (0.30 log units) away from the limit.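

In this assay, placing sulfamoyl instead of hydroxymethyl on this aromatic carbon, para to a large group, gives a clearly weaker inhibitor, with an at least 2.8-fold higher number from compound 1 to compound 4 (0.45 log units; beyond the scatter). Within the data shown here, the earlier sized step involved a different pair of groups, so this is the first evidence that the group at this place on compound 1 can be changed only at a clear cost in this assay, even though neither group carries a net charge and both have a hydrogen-bond donor and acceptor. The full size of the loss cannot be given, because the result for compound 4 is a limit and not a number: the limit of > 10000 nM in this assay, at which 2 of the 4 values shown sit.

The compounds shown leave open whether an amine, a carboxylic acid or a longer alcohol chain on this carbon would stay in the measurable range, as hydroxymethyl does in compound 1, or reach the limit as sulfamoyl does in compound 4. They also do not tell which part of sulfamoyl, the sulfur with its two oxygens or the nitrogen, goes with the loss.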